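The source may hold more compounds than are shown below. What is called first, only, known or untested is meant among the compounds shown, and "the series" means these compounds.

Measured compounds in a physicochemical assay for lipophilicity; on this read-out lower numbers stand for lower lipophilicity and higher numbers for higher lipophilicity:
compound 1, `CC(/C=C/CC(C)CCCC(C)C)=C\C(=O)OCC(C)C`, gives 7.69
compound 2, `CCN(CC)C(=O)/C=C(C)/C=C/CC(C)CCCC(C)C`, gives 6.02
compound 3, `CCC(=O)/C=C(C)/C=C/CC(C)CCCC(C)C`, gives 6.27; 6.68 (2 entries)

Compound 2 stands lowest of the two single numbers; its nearest neighbour is compound 1, and the measured step was a number 1.67 log units lower from compound 1 to compound 2 (beyond the scatter), the diethylamino in place of isobutoxy on the carbonyl carbon. Compound 3 carries an ethyl on that carbonyl carbon and its repeats, (the several entries of compound 3 in this assay, 6.27; 6.68 (2 entries)), sit well above compound 2.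

Compound 4, `CCCC(=O)/C=C(C)/C=C/CC(C)CCCC(C)C`, is not yet measured. Against compound 2 the difference is propyl in place of diethylamino on a carbonyl carbon. Going by the values given here, the only measured step, the one from compound 1 to compound 2, was large and downward on leaving the diethylamino, so reversing to a plain chain is expected to go upward, beyond the scatter. Compound 4 is thus expected at 7, range 6.5 to 7.5, an expected step of a number 0.98 log units higher from compound 2 to compound 4 (beyond the scatter).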

Compound 4, partition coefficient: 6.81
The estimate for compound 4 lay 0.19 log units above the measured number; low and high end bracket the measured number.
By their numbers in this assay, from the lowest: compound 2; then compound 4; then compound 1.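

In this assay, propyl in place of diethylamino on the carbonyl carbon gives a number 0.79 log units higher from compound 2 to compound 4 (beyond the scatter), while propyl in place of isobutoxy gives a number 0.88 log units lower from compound 1 to compound 4 (beyond the scatter). This position therefore separates all three groups, with propyl lying between the other two and both steps beyond the scatter. The ethyl analogue, compound 3, offers no single number to set against compound 4: the several entries of compound 3 in this assay, 6.27; 6.68 (2 entries)

As far as these compounds go, whether a longer chain, a primary amine or a carboxylic acid on the carbonyl carbon would fit this order remains open.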